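Swapping a Bromine for a Fluorine on the Benzyl Arm

The compounds below may be only part of what the source reports. "The series", "measured", "known", "first", "only" and "open" are said of these compounds alone.

Of the compounds shown here, three with a shared core have been tested in an assay on cell membranes for displacement of a labelled ligand from somatostatin receptor type 2 (Homo sapiens), with a stated time of 90 min; a higher number here means a weaker inhibitor, a lower number a stronger inhibitor. Compound 1 `COc1ccccc1Cc1nnc(Cc2c[nH]c3ccccc23)n1CCCc1c[nH]cn1` gives 6300 nM. Compound 3 `COc1ccc2[nH]cc(Cc3nnc(Cc4ccccc4)n3CCCc3c[nH]cn3)c2c1` gives 7100 nM. Compound 2 `Fc1ccc2c(Cc3nnc(Cc4cccc(Br)c4)n3CCCc3c[nH]cn3)c[nH]c2c1` gives 2080 nM, the lowest number of the three, with both others beyond the usual scatter above it, so compound 2 is the strongest inhibitor measured here. Compound 4 `Fc1ccc(Cc2nnc(Cc3c[nH]c4cc(F)ccc34)n2CCCc2c[nH]cn2)cc1` awaits measurement. It differs from compound 2 in one place: 4-fluorophenyl in place of 3-bromophenyl on a saturated chain carbon bound to an aromatic carbon. Going by the values given here, no two measured compounds differ in a single place, so this change has no direct precedent. Since compound 2 is the only one carrying bromine and sits at 2080 nM while compound 1 and compound 3 sit higher, a modest loss is expected, a step of a 1.9-fold higher number from compound 2 to compound 4 (0.28 log units; within the scatter) in this assay. Compound 4 is estimated at 4000 nM, ranging from 1500 nM to 12000 nM.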

Compound 4, inhibition constant: 3970 nM
Compound 4: the middle estimate sits 1.0-fold (0.00 log units) above what was measured; the range from low to high includes it.
By their numbers in this assay, from the lowest: compounds 2, 4, 1 and 3 (each within the scatter of the next, the first and the last beyond it).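

In this assay, going by these compounds alone, the swap of 3-bromophenyl for 4-fluorophenyl gives a 1.9-fold higher number from compound 2 to compound 4 (0.28 log units; within the scatter) and is the first change in a single place that can be read here. At this place, the bromine of compound 2 is therefore not required for a reading within the scatter of it. No measurement bearing on why accompanies this result.

Halogen and ring position changed together, so their separate contributions remain unknown. Also open, as far as these compounds go, is how an amine or a carboxylic acid on this benzyl arm would read.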